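A Charged Group on the Saturated Ring of Compound 3

The source may hold more compounds than are shown below. What is called first, only, known or untested is meant among the compounds shown, and "the series" means these compounds.

Compound 1, `CC(C)CN1CCc2c(sc(NC(=O)Nc3ccc(Cl)cc3)c2C(N)=O)C1`: 4510 nM
Compound 2, `CCN1CCc2c(sc(NC(=O)Nc3ccc(Cl)cc3)c2C(=O)NC)C1`: > 25000 nM
Compound 3, `CCC(C)(C)C1CCc2c(sc(NC(=O)Nc3ccc(Cl)cc3)c2C(N)=O)C1`: > 25000 nM

Of the compounds shown here, three that share a core have been measured in a functional assay (strain AB) with Danio rerio as the target, read by microscopy, with a stated time of 1 h; a higher number here means that more compound is needed for the effect, a lower number that less compound is needed. Compound 1 gives 4510 nM. For compound 2 the result is only a limit of the assay, > 25000 nM. For compound 3 the result is likewise only a limit of the assay, > 25000 nM. For the measured compounds named here, compound 3 thus stands at the limit of > 25000 nM in this assay, at which 2 of the 3 values shown sit, with no number of its own, so no measured step leads away from it.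

Compound 4, `C[N+](C)(C)C1CCc2c(sc(NC(=O)Nc3ccc(Cl)cc3)c2C(N)=O)C1`, has not yet been measured. It differs from compound 3 in one place: a group of 4 heavy atoms (3 carbon, 1 nitrogen; no ring) in place of a group of 5 heavy atoms (5 carbon; no ring), on a saturated ring carbon.

Going by the values given here, with no measured step to lean on, and with compound 3 itself resting at a limit, there is no ground to expect compound 4 to come down to a number. Compound 4 is therefore estimated at 30000 nM, between 8000 nM and 80000 nM. The step from compound 3 to compound 4 is expected to be a step that the limit leaves unreadable from compound 3 to compound 4, that is, no movement beyond the scatter.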

Compound 4, half-maximal effective concentration: 5870 nM
Compound 4: the middle estimate sits 5.1-fold (0.71 log units) above what was measured; the measured number lies below the stated range.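

In this assay, the change at this saturated ring carbon, with 1,1-dimethylpropyl leaving and a group of net charge +1 entering, gives an at least 4.2-fold lower number from compound 3 to compound 4 (0.62 log units; beyond the scatter). For the compounds shown here, this is the first readable step at this position, and it shows that the group on this ring carbon can decide whether the shared core reaches a measured number in this assay at all. The true size of the step remains unknown because compound 3 rests at a limit, not a number: the limit of > 25000 nM in this assay, at which 2 of the 4 values shown sit.

The compounds shown do not separate the net charge from the other differences between the two groups. Going by these compounds, how a tert-butyl group, an uncharged amine or a carboxylic acid on this ring carbon would compare with the group in compound 4 also remains open.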